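From 2-methylphenyl to 4-propylphenyl in compound 3

The source may report more compounds than this note shows. Statements on the series, on what has been measured and on what is new or still open speak of the compounds shown alone.

In an ADME assay on BJ cells (Homo sapiens) for cytotoxicity, with a stated time of 72 h (on this read-out lower numbers stand for an effect already at smaller amounts and higher numbers for an effect only at larger amounts of compound), compound 1 `Cc1nn(-c2ccccc2)c2nc(-c3ccccc3)c(C#N)c(-c3ccccc3O)c12` gives > 23000 nM, which is a limit of the assay. Going by the values given here, compound 2 `Cc1ccccc1-c1nc2c(c(C)nn2-c2ccccc2)c(-c2ccccc2O)c1C#N` gives 21000 nM, the only actual number so far. Compound 3 `CCCc1ccc(-c2nc3c(c(C)nn3-c3ccccc3)c(-c3ccccc3O)c2C#N)cc1` carries 4-propylphenyl in place of 2-methylphenyl on an aromatic carbon. Among the compounds with values here, the one measured step, methyl in place of hydrogen on an aromatic carbon, is an at least 1.0-fold lower number from compound 1 to compound 2 (0.03 log units; that floor lies within the scatter), and it alters this same group. No change beyond the scatter is therefore expected, and the estimated step is a 1.3-fold lower number from compound 2 to compound 3 (0.12 log units; within the scatter). For compound 3 the estimate is 16000 nM, with an expected range of 7000 nM to 30000 nM.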

Compound 3, half-maximal effective concentration: 22500 nM
Compound 3: middle estimate off by 1.4-fold (0.15 log units), on the low side; the measured number falls inside the stated range.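

In this assay, 4-propylphenyl in place of 2-methylphenyl on this aromatic carbon gives a 1.1-fold higher number from compound 2 to compound 3 (0.03 log units; within the scatter), so this position takes the larger group with no change beyond the scatter. Set against compound 1, whose reading is a limit, the propyl group gives an at least 1.0-fold lower number from compound 1 to compound 3 (0.00 log units; that floor lies within the scatter). The true size of that step cannot be told because the reading for compound 1 stops at a limit: the limit of > 23000 nM in this assay, at which 1 of the 3 values shown sits.

Going by these compounds, whether any group here can move the number beyond the scatter stays open. So does the effect of an amine or a carboxylic acid on this phenyl ring.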